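Working notes: hydroxy in place of iodo in compound 4

This account rests on a few compounds, and the source may have more. Where it says the series, first, only, none or still open, it means among the compounds named here.

compound 1 `CCOOC1(OOCC)CCCCCCCCCCC1`: 10000 nM
compound 2 `C=C(C)COOC1(OOC)CCCCCCCCCCC1`: 17000 nM
compound 3 `COOC1(OOCCCCCCI)CCCCCCCCCCC1`: 86000 nM

In a functional assay on FM3A cells (Mus musculus) for cytotoxicity (a lower number here means that less compound is needed, a higher number that more compound is needed for the effect), compound 3 stands highest of the three, at 86000 nM, beyond the scatter from both others. Next comes compound 4 `COOC1(OOCCCCCCO)CCCCCCCCCCC1`, with the change hydroxy in place of iodo on a saturated chain carbon, six bonds along the chain from an oxygen. Within the data shown here, one measured step bears on this chain, and only indirectly: a 5.1-fold higher number from compound 2 to compound 3 (0.70 log units; beyond the scatter), with 5-iodopentyl in place of 1-methylethenyl. Among the measured compounds shown here, no measured step covers the exchange of iodo for hydroxy, so the guidance is weak. A modest downward step is expected, no larger than that one. For compound 4 the estimate is 40000 nM, with an expected range of 12000 nM to 120000 nM. The estimated change is a 2.2-fold lower number from compound 3 to compound 4 (0.33 log units; beyond the scatter).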

Compound 4, half-maximal effective concentration: 1600 nM
Compound 4: middle estimate off by 25-fold (1.40 log units), on the high side, and the stated range ends above it.
By their numbers in this assay, from the lowest: compound 4; then compounds 1 and 2 (each within the scatter of the next); then compound 3.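

In this assay, this place on the chain responds strongly to the group it carries: hydroxy in place of iodo gives a 54-fold lower number from compound 3 to compound 4 (1.73 log units; beyond the scatter) and so reverses the direction seen with the iodo chain. Against the 1-methylethenyl side, the 5-hydroxypentyl chain gives an 11-fold lower number from compound 2 to compound 4 (1.03 log units; beyond the scatter) while 5-iodopentyl had moved the other way. No available evidence explains this difference between hydroxy and iodo.

Going by these compounds, whether the low number is specific to hydroxy, or would also appear with an amine or a carboxylic acid at this place, stays open. So does the effect of a longer chain carrying the same hydroxy.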